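Series notes: aryl-triazole variation, compound 3 to compound 4

A few compounds are considered here, and "the series" means these few. Any claim that something is new, unique, unknown or untested is made for them only; others in the source may bear on it.

Compound 3 `CCS[C@@H]1[C@H](SCC)[C@@H](Cn2cc(-c3ccc(C)cc3)nn2)O[C@H]1n1cc(C)c(=O)[nH]c1=O` carries a 4-methylphenyl on the triazole and gives 77500 nM in a functional assay on HeLa cells (Homo sapiens) for cytotoxicity, read by MTT assay, with a stated time of 72 h (on this read-out higher numbers stand for an effect only at larger amounts of compound and lower numbers for an effect already at smaller amounts), the highest number among the three measured compounds. Compound 1 `CCS[C@@H]1[C@H](SCC)[C@@H](Cn2cc(-c3ccccc3)nn2)O[C@H]1n1cc(C)c(=O)[nH]c1=O` gives 1890 nM, compound 2 `CCS[C@@H]1[C@H](SCC)[C@@H](Cn2cc(-c3ccccc3C(F)(F)F)nn2)O[C@H]1n1cc(C)c(=O)[nH]c1=O` gives 54300 nM. The measured steps are a 29-fold higher number from compound 1 to compound 2 (1.46 log units; beyond the scatter) and a 41-fold higher number from compound 1 to compound 3 (1.61 log units; beyond the scatter), both large, while a 1.4-fold higher number from compound 2 to compound 3 (0.15 log units; within the scatter) is within the scatter.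

Compound 4 `CCS[C@@H]1[C@H](SCC)[C@@H](Cn2cc(-c3cccs3)nn2)O[C@H]1n1cc(C)c(=O)[nH]c1=O` replaces the aryl group: thiophen-2-yl in place of 4-methylphenyl on an aromatic carbon. Among the measured compounds shown here, no measured pair involves thiophen-2-yl, so no step bears on it directly. What the measured steps show is that adding trifluoromethyl or methyl to the ring of compound 1 raised the number sharply; compound 4 carries a ring without such a substituent, so its number is expected to move back toward that of compound 1, though by an uncertain amount. The expected step is a 7.8-fold lower number from compound 3 to compound 4 (0.89 log units; beyond the scatter), a lower number. Compound 4 is estimated at 10000 nM, within a range from 2000 nM to 80000 nM.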

Compound 4, half-maximal effective concentration: 54900 nM
Compound 4: the middle estimate sits 5.5-fold (0.74 log units) below what was measured; low and high end bracket the measured number.
By their numbers in this assay, from the lowest: compound 1; then compounds 2, 4 and 3 (each within the scatter of the next).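

In this assay, thiophen-2-yl, which carries no further substituent, does not bring the number back to that of compound 1: a 29-fold higher number from compound 1 to compound 4 (1.46 log units; beyond the scatter). The lack of a substituent on the aryl ring is therefore not enough to give the low number, and thiophen-2-yl cannot be told apart from the two substituted phenyl groups, with a 1.4-fold lower number from compound 3 to compound 4 (0.15 log units; within the scatter) and a 1.0-fold higher number from compound 2 to compound 4 (0.00 log units; within the scatter). Among these four compounds, only the plain phenyl of compound 1 stands apart, and nothing available bears on a cause for this.

On these data alone, it remains open whether the low number is specific to phenyl at this position or is shared by other aryl groups, such as pyridin-2-yl. Also open, as far as these compounds go, is how the number responds to a phenyl bearing an amine or a carboxylic acid, or to a longer alkyl chain in place of the ring.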